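Compound 3: one methoxy fewer than compound 1

This account rests on a few compounds, and the source may have more. Where it says the series, first, only, none or still open, it means among the compounds named here.

Within the data shown here, compound 1 `C=C1[C@@H](OC(C)=O)C[C@@H]2[C@](C)(CO[Si](C)(C)C(C)(C)C)[C@H](OC(C)=O)CC[C@@]2(C)[C@@H]1C[C@@H](Nc1ccc(OC)c(OC)c1)C1=CCOC1=O` gives 5330 nM in a functional assay on HT-29 cells (Homo sapiens) for cytotoxicity, read by sulforhodamine B assay (on this read-out lower numbers stand for stronger inhibition and higher numbers for weaker inhibition), the lowest of the two numbers so far. Compound 2 `C=C1[C@@H](OC(C)=O)C[C@@H]2[C@](C)(COC=O)[C@H](OC(C)=O)CC[C@@]2(C)[C@@H]1C[C@@H](Nc1ccc(OC)c(OC)c1)C1=CCOC1=O` gives 42800 nM; the step of an 8.0-fold higher number from compound 1 to compound 2 (0.90 log units; beyond the scatter) sits on an oxygen on a saturated carbon and leaves the (3,4-dimethoxyphenyl)amino group untouched. Compound 3 `C=C1[C@@H](OC(C)=O)C[C@@H]2[C@](C)(CO[Si](C)(C)C(C)(C)C)[C@H](OC(C)=O)CC[C@@]2(C)[C@@H]1C[C@@H](Nc1cccc(OC)c1)C1=CCOC1=O` differs from compound 1 by hydrogen in place of methoxy on an aromatic carbon. Among the measured compounds shown here, no measured step bears on this change, so the expectation is a step within the scatter, with wide uncertainty. The expected step is a 1.3-fold higher number from compound 1 to compound 3 (0.12 log units; within the scatter). Compound 3 is therefore estimated at 7000 nM, between 2500 nM and 25000 nM.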

Compound 3, half-maximal inhibitory concentration: > 50000 nM
Compound 3: a limit, no number (the forecaster's own chance of this, stated with the estimate: 5%); middle value at least 7.1-fold (0.85 log units) from the limit.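

Among these compounds, the (3,4-dimethoxyphenyl)amino group stayed fixed in the earlier pair, and this is the first change read on it: in this assay, hydrogen in place of methoxy gives an at least 9.3-fold higher number from compound 1 to compound 3 (0.97 log units; beyond the scatter). This step is beyond the scatter, so in this pair the read-out depends on the methoxy para to a large group. Compound 3 stands at a limit of the assay, not at a number: the limit of > 50000 nM in this assay, at which 1 of the 3 values shown sits.

As far as these compounds go, whether a hydroxyl, a fluorine or an ethoxy in this place would keep the value of compound 1 stays open. So does whether the same change has a comparable result on the core of compound 2.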